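Working notes: from compound 1 to unmeasured compound 4

The source may hold more compounds than are shown below. What is called first, only, known or untested is meant among the compounds shown, and "the series" means these compounds.

Measured so far:
compound 1 `CCOC(=O)C1=C(Nc2ccccc2)S/C(=C\c2cccc(C(=O)O)c2)C1=O` — 16200 nM
compound 2 `CCOC(=O)C1=C(Nc2ccccc2)S/C(=C\c2cc(OC)c(O)c(OC)c2)C1=O` — 31700 nM
compound 3 `CCOC(=O)C1=C(Nc2cccc(F)c2)S/C(=C\c2ccc[nH]2)C1=O` — > 100000 nM (assay limit)

In a functional assay on K562 cells (Homo sapiens) for inhibition, read by MTT assay, with a stated time of 72 h (a lower number here means a stronger inhibitor, a higher number a weaker inhibitor), compound 1 gives 16200 nM, and among the two numbers reported it stands at the lowest, though the gap to its nearest neighbour, compound 2 at 31700 nM, lies within the scatter, so no order between these two can be drawn. Compound 3 yields only a limit in this assay, > 100000 nM (the limit of > 100000 nM in this assay, at which 1 of the 3 values shown sits), and not a number.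

Compound 4 `CCOC(=O)C1=C(Nc2ccccc2)S/C(=C\c2cc3ncccc3[nH]2)C1=O` has not yet been run in this assay. Relative to compound 1 it carries a group of 9 heavy atoms (7 carbon, 2 nitrogen; one five-membered aromatic ring with 1 hetero atom, one six-membered aromatic ring with 1 hetero atom) in place of a group of 9 heavy atoms (7 carbon, 2 oxygen; one six-membered aromatic ring of carbon only), on a double-bonded chain carbon bound to a double-bonded ring carbon. Among the compounds with values here, no measured pair differs in exactly this way, so the size of the step has to be judged without a direct precedent. Within the data shown here, compound 3, the one measured compound lacking a carboxyphenyl group, sits at the limit, but it differs from compound 1 in more than one place and gives no clean read on this change alone.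

For compound 4 in this assay a step of a 1.7-fold higher number from compound 1 to compound 4 (0.24 log units; within the scatter) toward a weaker value is expected, modest in size and possibly no more than the scatter. Compound 4 is estimated at 28000 nM, with a range from 7000 nM to 100000 nM.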

Compound 4, half-maximal inhibitory concentration: 6600 nM
Compound 4: the middle estimate sits 4.2-fold (0.63 log units) above what was measured; the measured number lies below the stated range.
By their numbers in this assay, from the lowest: compound 4; then compounds 1 and 2 (each within the scatter of the next). At a limit, above all of these: compound 3.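

The position on the double-bonded chain carbon bound to a double-bonded ring carbon accepts a change of ring type without loss in this assay: the exchange of the 3-carboxyphenyl group for the two-ring group gives a 2.5-fold lower number from compound 1 to compound 4 (0.39 log units; beyond the scatter). Within the data shown here, this is the first step that changes one place only, and it shows that the carboxylic acid is not required for activity at this level in this assay, with the heavy-atom count, the hydrogen-bond donor and acceptor counts and the net charge the same on both sides of the change. Nothing measured on these compounds bears on the origin of this step, so the difference remains an observation on one pair.

One pair cannot separate the contribution of the ring nitrogens from that of the two-ring shape, and an all-carbon naphthyl group at this place, or a two-ring group carrying an amine or a methoxy group, would address that question. As far as these compounds go, whether the step holds with a different group on the anilino nitrogen, such as the 3-fluorophenyl ring, also remains open.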